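A few compounds are considered here, and "the series" means these few. Any claim that something is new, unique, unknown or untested is made for them only; others in the source may bear on it.

Measured in a functional assay on MDA-MB-231 cells (Homo sapiens) for antiproliferative activity, read by XTT assay, with a stated time of 72 h; a higher number here means a weaker inhibitor, a lower number a stronger inhibitor:

compound 1 `COc1ccc(-c2cc3ccccc3nc2/C=C/C(=O)c2ccco2)cc1` — 630 nM
compound 2 `COc1ccc(-c2cc3ccccc3nc2/C=C/C(=O)c2ccccn2)cc1` — 740 nM

Compound 2 and compound 1 share the same core and the same enone bridge and differ only in the aryl group on the carbonyl carbon; their two values in this assay lie within the scatter of each other, the step of a 1.2-fold higher number from compound 1 to compound 2 (0.07 log units; within the scatter) being too small to read as a change. Among the measured compounds shown here, compound 2 therefore stands level with compound 1 on the numbers so far.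

Compound 3 `COc1ccc(-c2cc3ccccc3nc2/C=C/C(=O)c2ccc(Br)s2)cc1` is the next member and is not yet measured. It differs from compound 2 as follows: 5-bromothiophen-2-yl in place of pyridin-2-yl on a carbonyl carbon. For the measured compounds named here, the only measured step that bears on this change is a 1.2-fold higher number from compound 1 to compound 2 (0.07 log units; within the scatter), which exchanged one heteroaryl group for another at the same carbonyl carbon and stayed within the scatter. On that basis no step beyond the scatter is expected for compound 3 either, in either direction, so the expected step is a 1.1-fold lower number from compound 2 to compound 3 (0.02 log units; within the scatter). The estimate for compound 3 in this assay is 700 nM, with a range of 300 nM to 1600 nM.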

Compound 3, half-maximal inhibitory concentration: < 100 nM
Compound 3 ended at the assay's limit; the forecaster's own chance of this, stated with the estimate: 3%; middle value at least 7.0-fold (0.84 log units) from the limit.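

The aryl group on the carbonyl carbon is not a silent position in this assay: the earlier heteroaryl exchange left the values within the scatter, but 5-bromothiophen-2-yl gives an at least 7.4-fold lower number from compound 2 to compound 3 (0.86 log units; beyond the scatter) and an at least 6.3-fold lower number from compound 1 to compound 3 (0.79 log units; beyond the scatter). Both steps lie beyond the scatter, and the one from pyridin-2-yl comes with no difference in heavy-atom count, hydrogen-bond donors, hydrogen-bond acceptors or net charge, so these counts do not separate the two groups. For compound 3 the reading is a limit of the assay and not a number: the limit of < 100 nM in this assay, at which 1 of the 3 values shown sits.

The change brings in a thiophene ring and a bromine together, so the compounds shown leave open which of the two goes with the step, and how plain thiophen-2-yl, 5-chlorothiophen-2-yl or 5-bromofuran-2-yl would read at this carbonyl carbon. On these data alone, how far the true value of compound 3 lies past the limit also stays open, so both steps give only a minimum size.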